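The source may report more compounds than this note shows. Statements on the series, on what has been measured and on what is new or still open speak of the compounds shown alone.

Within the data shown here, compound 2 `COc1cc(OC)c(C(=O)/C=C/c2ccc(Br)cc2)c(OC)c1` gives 68% in a functional assay on HCT-116 cells (Homo sapiens), read by fluorescence and BrdU incorporation, with a stated time of 48 h, tested at 10 uM (a lower number here means a stronger effect, a higher number a weaker effect of the compound at the concentration tested), the higher of the two values measured so far, while compound 1 `COc1cc(OC)c(C(=O)/C=C/c2ccc(Cl)cc2)c(OC)c1` gives 18%. Compound 3 `COc1cc(OC)c(C(=O)/C=C/c2ccc(F)cc2)c(OC)c1` has not yet been measured. It differs from compound 2 by fluoro in place of bromo on an aromatic carbon. Among the measured compounds shown here, only one measured step bears on this change, and it runs the other way: a number 50 percentage points higher from compound 1 to compound 2 (beyond the scatter). Exchanging one halogen for another thus moved the number a long way, so moving away from bromo again is expected to bring it back down, by a number 43 percentage points lower from compound 2 to compound 3 (beyond the scatter). Compound 3 is therefore estimated at 25%, within 5% to 60%.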

Compound 3, a percentage reported as activity, at one concentration (the size of the read-out at that concentration, not a potency): 23%
Beside the measured number, compound 3's estimate is 2 percentage points above it; the range from low to high includes it.
By their numbers in this assay, from the lowest: compounds 1 and 3 (each within the scatter of the next); then compound 2.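

In this assay fluoro in place of bromo gives a number 45 percentage points lower from compound 2 to compound 3 (beyond the scatter) and so bromo now stands apart from two other halogens at this place on the ring, not from chloro alone. Fluoro in place of chloro gives a number 5 percentage points higher from compound 1 to compound 3 (within the scatter) and these two halogens cannot be told apart here. No measurement shown explains why bromo alone differs. Going by these compounds, whether iodo would stay with bromo remains open. So does whether an amine or a nitrile at this place would give a low or a high number.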